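Hydroxy in Place of Bromo on a Shared Core

The source may report more compounds than this note shows. Statements on the series, on what has been measured and on what is new or still open speak of the compounds shown alone.

Compound 1 `O=c1cc(-n2cc(COc3ccccc3)nn2)c2cc(Br)ccc2o1` is the reference point here. Among the compounds with values here, in a functional assay on MCF7 cells (Homo sapiens) for antiproliferative activity, read by MTT assay, with a stated time of 48 h (on this read-out lower numbers stand for stronger inhibition and higher numbers for weaker inhibition), compound 1 gives 1720 nM, the lowest of the two numbers measured so far. Within the data shown here, its only measured neighbour is compound 2 `COC(=O)c1ccccc1OCc1cn(-c2cc(=O)oc3ccc(Br)cc23)nn1`, which in this assay gives 34100 nM. Among the measured compounds shown here, the one measured step, a 20-fold higher number from compound 1 to compound 2 (1.30 log units; beyond the scatter), is a methoxycarbonyl in place of hydrogen on an aromatic carbon of the phenoxy part, far from the fused ring system.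

Compound 3 `O=c1cc(-n2cc(COc3ccccc3)nn2)c2cc(O)ccc2o1` has not been measured. Its change from compound 1 is hydroxy in place of bromo on an aromatic carbon: a hydroxy in place of bromo on an aromatic carbon of a six-membered aromatic ring of carbon only, part of a fused system of two rings, meta to a fused ring and para to a fused ring. For the measured compounds named here, no measured step bears on this change; the only step known alters the opposite end of the molecule and leaves this position untouched, so it gives no direct guide. With nothing to point either way, a modest step is expected, a 2.3-fold higher number from compound 1 to compound 3 (0.37 log units; beyond the scatter), toward a somewhat higher number. Compound 3 is therefore estimated at 4000 nM, with a range from 1200 nM to 13000 nM.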

Compound 3, half-maximal inhibitory concentration: > 50000 nM
Compound 3: only a limit was reported (the forecaster's own chance of this, stated with the estimate: 5%); at least 12-fold (1.09 log units) between middle value and limit.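

In this assay compound 3 gives > 50000 nM, which is a limit of the assay and not a number. Hydroxy in place of bromo gives an at least 29-fold higher number from compound 1 to compound 3 (1.46 log units; beyond the scatter), so what sits at this position matters, whereas the earlier compounds had shown a large change only from the phenoxy part, with a 20-fold higher number from compound 1 to compound 2 (1.30 log units; beyond the scatter). The full size of the new step stays unknown, because the reading for compound 3 ends at a limit: the limit of > 50000 nM in this assay, at which 1 of the 3 values shown sits.

Among the compounds shown, this position carries only bromo or hydroxy, so they cannot separate the effect of losing bromo from the effect of adding hydroxy. A plain hydrogen, a chlorine, a methoxy group or an amine on the same carbon would help to tell these two readings apart and would show whether bromo is a special case or one of several groups that can stand here.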